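This account rests on a few compounds, and the source may have more. Where it says the series, first, only, none or still open, it means among the compounds named here.

Measured so far:
- compound 1 `Cn1c(Sc2c(F)cc(C(=O)NO)cc2F)nnc1-c1cccnn1`: 98%
- compound 2 `Cn1c(Sc2c(F)cc(C(=O)NO)cc2F)nnc1-c1ncccc1F`: 100%

In an ADME assay on a cell-free system (plasma, Rattus norvegicus) for metabolic stability, read by LC-MS, with a stated time of 4 h, tested at 100 uM (a higher number here means that more of the compound is left, a lower number that less of the compound is left), compound 2 gives 100%, within the scatter of compound 1 at 98%. Compound 3 `Cc1cc(-c2nnc(Sc3c(F)cc(C(=O)NO)cc3F)n2C)nn1C` is still unmeasured and differs from compound 2 at one place, where 1,5-dimethyl-1H-pyrazol-3-yl replaces 3-fluoropyridin-2-yl: 1,5-dimethyl-1H-pyrazol-3-yl in place of 3-fluoropyridin-2-yl on an aromatic carbon. For the measured compounds named here, one measured step bears on this place, a number 2 percentage points higher from compound 1 to compound 2 (within the scatter), and it swapped one six-membered aromatic ring for another. A five-membered aromatic ring has not yet been measured there, so the expectation rests on that single step, and no step beyond the scatter is expected in this assay. The expected change is a number 3 percentage points lower from compound 2 to compound 3 (within the scatter). For compound 3 the estimate is 97%, with a range of 88% to 100%.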

Compound 3, percent of the compound remaining: 80%
Beside the measured number, compound 3's estimate is 17 percentage points above it; measured number outside the range, below it.
By their numbers in this assay, from the lowest: compound 3; then compounds 1 and 2 (each within the scatter of the next).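

In this assay this position turns out not to accept every aromatic ring alike: 1,5-dimethyl-1H-pyrazol-3-yl brings a number 20 percentage points lower from compound 2 to compound 3 (beyond the scatter) and a number 18 percentage points lower from compound 1 to compound 3 (beyond the scatter) whereas the swap between the two six-membered aromatic rings stayed within the scatter. For the compounds shown here, the first change beyond the scatter at this place thus comes with a five-membered aromatic ring that also carries two methyl groups. No measured evidence accounts for this drop. The compounds shown leave open whether the drop belongs to the five-membered ring or to its methyl groups, and how an amine or a carboxylic acid on the ring at this position would fare.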